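Working notes: alkyl trimming in a sulfonyl aryl ether series

The source may report more compounds than this note shows. Statements on the series, on what has been measured and on what is new or still open speak of the compounds shown alone.

Compound 1 `CCCN(CCC)CCCOc1ccc(S(=O)(=O)c2c(C(C)C)cn3ccccc23)cc1` carries a dipropylamino group and an isopropyl group; in a functional assay (aorta) with Rattus norvegicus as the target (on this read-out higher numbers stand for weaker inhibition and lower numbers for stronger inhibition), compound 1 gives 102 nM. Compound 2 `CCCCN(CCCC)CCCOc1ccc(S(=O)(=O)c2c(C(C)C)cn3ccccc23)cc1` has dibutylamino in place of dipropylamino, and in this assay compound 2 gives 21.6 nM; the step is a 4.7-fold lower number from compound 1 to compound 2 (0.67 log units; beyond the scatter). Compound 3 `CCCCN(CCCC)CCCOc1ccc(S(=O)(=O)c2c(C(C)(C)C)cn3ccccc23)cc1` holds a tert-butyl group where compound 2 holds isopropyl, and in this assay compound 3 gives 51.9 nM. The change from compound 3 to compound 2 is hydrogen in place of methyl on a saturated chain carbon bound to an aromatic carbon and two saturated chain carbons and brings a 2.4-fold lower number from compound 3 to compound 2 (0.38 log units; beyond the scatter). Compound 1 and compound 3 differ in more than one place; the difference between these two cores is not broken down here.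

Compound 4 `CCCN(CCC)CCCOc1ccc(S(=O)(=O)c2c(CC)cn3ccccc23)cc1` is the unmeasured analogue of compound 1, and the change is hydrogen in place of methyl on a saturated chain carbon bound to an aromatic carbon and a saturated chain carbon. This is the same kind of change as from compound 3 to compound 2, not the same: in compound 4 the carbon losing the methyl is bound to an aromatic carbon and one saturated chain carbon, in compound 2 to an aromatic carbon and two saturated chain carbons. The step from compound 1 to compound 4 in this assay is expected to be a 1.9-fold lower number from compound 1 to compound 4 (0.27 log units; within the scatter), somewhat smaller than a 2.4-fold lower number from compound 3 to compound 2 (0.38 log units; beyond the scatter), and the expectation rests on that measured step discounted for the different surroundings. Compound 4 is accordingly estimated at 55 nM, with a range from 25 nM to 130 nM.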

Compound 4, half-maximal inhibitory concentration: 150 nM
Compound 4: middle estimate off by 2.7-fold (0.44 log units), on the low side; measured number above the stated range.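

In this assay, going from isopropyl to ethyl with dipropylamino kept gives a 1.5-fold higher number from compound 1 to compound 4 (0.17 log units; within the scatter), a step that cannot be told apart from repeat measurement. Hydrogen in place of methyl therefore does not carry over at a fixed size between these two cores, and the measured steps differ: the same change on two cores in this assay, a 2.4-fold lower number (0.38 log units; beyond the scatter) from compound 3 to compound 2 and a 1.5-fold higher number (0.17 log units; within the scatter) from compound 1 to compound 4, 3.5-fold (0.55 log units) apart, beyond the scatter of two such steps This does not show which difference between the cores sets the gap, since the two steps differ both in the carbon that loses the methyl and in dibutylamino against dipropylamino, and two steps give no general rule for the series.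

Ethyl alongside dibutylamino, or tert-butyl alongside dipropylamino, would separate those two differences, and the compounds shown leave that question open. Also open, from the compounds shown here alone, is how a methyl group in the same place, or a dipentylamino group on the chain, would read in this assay.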